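This account rests on a few compounds, and the source may have more. Where it says the series, first, only, none or still open, it means among the compounds named here.

Series notes. Compound 3 `CC(=O)N1CCOC(CNC(=O)c2ccncc2Nc2cc(-c3ccc4ccn(C)c4c3)c3nccnc3c2)C1` stands at the highest number of the three in an assay for inhibition of 6-phosphofructo-2-kinase/fructose-2,6-bisphosphatase 3 (Homo sapiens), read by ADP-Glo, with a stated time of 2 h; a lower number here means a stronger inhibitor, a higher number a weaker inhibitor: compound 3 gives 93 nM, whereas compound 1 `CN1CCC(NC(=O)c2ccncc2Nc2cc(-c3ccc4ccn(C)c4c3)c3nccnc3c2)CC1` gives 38 nM and compound 2 `CC(=O)N1CCCC(NC(=O)c2ccncc2Nc2cc(-c3ccc4ccn(C)c4c3)c3nccnc3c2)C1` gives 11 nM. Both a 2.4-fold higher number from compound 1 to compound 3 (0.39 log units; beyond the scatter) and an 8.5-fold higher number from compound 2 to compound 3 (0.93 log units; beyond the scatter) lie beyond the scatter. Compound 4 `CN1CC(NC(=O)c2ccncc2Nc2cc(-c3ccc4ccn(C)c4c3)c3nccnc3c2)C1` carries 1-methylazetidin-3-yl in place of (4-acetylmorpholin-2-yl)methyl on an amide-type nitrogen. The measured step that bears most directly on this is a 2.4-fold higher number from compound 1 to compound 3 (0.39 log units; beyond the scatter), compound 1 bearing 1-methylpiperidin-4-yl on the same amide-type nitrogen; read in reverse it points to a lower number of modest size, and an 8.5-fold higher number from compound 2 to compound 3 (0.93 log units; beyond the scatter) points the same way. Compound 4 is therefore expected to show a 2.3-fold lower number from compound 3 to compound 4 (0.37 log units; beyond the scatter), an estimated 40 nM with a range of 15 nM to 110 nM.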

Compound 4, half-maximal inhibitory concentration: 30 nM
For compound 4 the middle estimate is 1.3-fold (0.12 log units) above the measured one; measured number inside the range.
By their numbers in this assay, from the lowest: compound 2; then compounds 4 and 1 (each within the scatter of the next); then compound 3.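

On the amide-type nitrogen of the shared core, the four-membered ring of 1-methylazetidin-3-yl reads level with the six-membered ring of 1-methylpiperidin-4-yl (a 1.3-fold lower number from compound 1 to compound 4 (0.10 log units; within the scatter)) in this assay. Replacing (4-acetylmorpholin-2-yl)methyl gives a 3.1-fold lower number from compound 3 to compound 4 (0.49 log units; beyond the scatter), but 1-acetylpiperidin-3-yl stays ahead, with a 2.7-fold higher number from compound 2 to compound 4 (0.44 log units; beyond the scatter) as the step to the azetidine. No measurement shown here accounts for these steps. Still open, on these data alone, is whether the acetyl group or the ring accounts for the step from compound 2. A 1-acetylazetidin-3-yl group on the same nitrogen would separate the two.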